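The compounds below may be only part of what the source reports. "The series", "measured", "known", "first", "only" and "open" are said of these compounds alone.

Compound 1 `Cc1ccc(C(=O)NC(=O)c2ccccc2O)cc1`: 46 ug/mL
Compound 2 `CC(C)c1ccc(C(=O)NC(=O)c2ccccc2O)cc1`: 19 ug/mL
Compound 3 `CC(C)(C)c1ccc(C(=O)NC(=O)c2ccccc2O)cc1`: 2.3 ug/mL

In an ADME assay on L6 cells (Rattus norvegicus) for cytotoxicity, read by resazurin assay, with a stated time of 72 h (a lower number here means a stronger inhibitor, a higher number a weaker inhibitor), compound 3 has the lowest of the three numbers, at 2.3 ug/mL. The other two compounds lie well above it, as a 20-fold lower number from compound 1 to compound 3 (1.30 log units; beyond the scatter) and an 8.3-fold lower number from compound 2 to compound 3 (0.92 log units; beyond the scatter) show.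

The next compound is compound 4 `O=C(NC(=O)c1ccccc1O)c1ccc(OC(F)(F)F)cc1`, and it carries a single change: trifluoromethoxy in place of tert-butyl on an aromatic carbon. Trifluoromethoxy has not yet been measured on the shared core, so no measured step matches this change directly. The nearest guides are the changes among the alkyl groups at the same place. Isopropyl in place of methyl gave a 2.4-fold lower number from compound 1 to compound 2 (0.38 log units; beyond the scatter), while tert-butyl in place of methyl gave a 20-fold lower number from compound 1 to compound 3 (1.30 log units; beyond the scatter). Only tert-butyl has reached the low end of this small set, and compound 4 gives that group up. A modest move to a higher number is therefore expected, and the estimated size of this move is a 3.5-fold higher number from compound 3 to compound 4 (0.54 log units; beyond the scatter). For compound 4 the estimate is 8 ug/mL, with an expected range of 2.5 ug/mL to 28 ug/mL.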

Compound 4, half-maximal inhibitory concentration: 84 ug/mL
The estimate for compound 4 lay 11-fold (1.02 log units) below the measured number; the measured number lies above the stated range.
By their numbers in this assay, from the lowest: compound 3; then compound 2; then compounds 1 and 4 (each within the scatter of the next).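

In this assay, this position turns out to depend on which group sits there, not only on how many heavy atoms it holds: trifluoromethoxy in place of tert-butyl, a swap that adds a heavy atom, gives a 37-fold higher number from compound 3 to compound 4 (1.56 log units; beyond the scatter). The same group in place of isopropyl gives a 4.4-fold higher number from compound 2 to compound 4 (0.65 log units; beyond the scatter), while in place of methyl it gives a 1.8-fold higher number from compound 1 to compound 4 (0.26 log units; within the scatter), so trifluoromethoxy and methyl cannot be told apart here, and the climb through the alkyl groups does not carry over to this oxygen-linked group. Nothing in the data shown speaks to the reason for these shifts.

The compounds shown leave open whether the low number belongs to tert-butyl alone or is shared by other branched groups, such as a cyclohexyl ring or a longer branched chain. They also leave open whether methoxy or trifluoromethyl would fall with compound 3 or with compound 4.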